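The source may hold more compounds than are shown below. What is called first, only, known or untested is meant among the compounds shown, and "the series" means these compounds.

Going by the values given here, in an assay on CHO cells for displacement of a labelled ligand from 5-hydroxytryptamine receptor 1B (Homo sapiens) (a lower number here means a stronger inhibitor, a higher number a weaker inhibitor), compound 1 `c1ccc(CNCC2CCN(CCCc3c[nH]c4ccc(-n5cnnc5)cc34)CC2)cc1` gives 28 nM, the highest of the three numbers measured so far. Compound 2 `CC(=O)Nc1ccc([C@H](C)NCC2CCN(CCCc3c[nH]c4ccc(-n5cnnc5)cc34)CC2)cc1` gives 9.3 nM and compound 3 `CC(=O)Nc1ccc([C@@H](C)NCC2CCN(CCCc3c[nH]c4ccc(-n5cnnc5)cc34)CC2)cc1` gives 8.9 nM. These two are mirror forms of one another; the fact that compounds 2 and 3 differ only in the configuration as drawn and the step of a 1.0-fold lower number from compound 2 to compound 3 (0.02 log units; within the scatter) lies within the scatter. Putting 1-(4-acetamidophenyl)ethyl in place of benzyl on the amine nitrogen brought a 3.0-fold lower number from compound 1 to compound 2 (0.48 log units; beyond the scatter) and a 3.1-fold lower number from compound 1 to compound 3 (0.50 log units; beyond the scatter), both beyond the scatter yet modest.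

Compound 4 `CC(C)=CCN(C)C1CCN(CCCc2c[nH]c3ccc(-n4cnnc4)cc23)CC1` differs from compound 1 at a saturated ring carbon of the six-membered non-aromatic ring with one nitrogen: methyl(3-methylbut-2-en-1-yl)amino in place of (benzylamino)methyl on a saturated ring carbon. The six-membered aromatic ring of carbon only leaves, and with it the single hydrogen-bond donor; what enters has no ring, one double bond outside aromatic rings and one hydrogen-bond acceptor. Among the compounds with values here, none of the measured steps tests this change: all three measured compounds keep the aromatic ring and vary only the group on the amine nitrogen or its configuration, and those variations moved the number by modest amounts. Within the data shown here, compound 4 is the only one without an aromatic ring in this part, so its number is expected to be somewhat higher than that of compound 1, with an estimated step of a 2.1-fold higher number from compound 1 to compound 4 (0.33 log units; beyond the scatter). The estimate for compound 4 is 60 nM, within a range from 20 nM to 200 nM.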

Compound 4, half-maximal inhibitory concentration: 41 nM
The estimate for compound 4 lay 1.5-fold (0.17 log units) above the measured number, within the range that was stated.
By their numbers in this assay, from the lowest: compounds 3 and 2 (each within the scatter of the next); then compounds 1 and 4 (each within the scatter of the next).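

Putting methyl(3-methylbut-2-en-1-yl)amino in place of (benzylamino)methyl on the saturated ring carbon gives, in this assay, a 1.5-fold higher number from compound 1 to compound 4 (0.17 log units; within the scatter). Compounds 1, 2 and 3 all carry a six-membered aromatic ring of carbon only in this group, so they could not show what happens without one; compound 4 shows that a group with no ring and no hydrogen-bond donor can stand at this place with a number that stays within the scatter of that of compound 1. Nothing measured on these compounds speaks to why the number stays so close after such a large change in the group.

This one step removes the aromatic ring and the hydrogen-bond donor and adds a double bond all at once, so the compounds shown leave open which of these changes matters for the number, or whether their effects simply offset one another. A cyclohexyl ring in place of the aromatic ring, or a plain dimethylamino group on the same ring carbon, would pull these changes apart.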